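Extending the ether chain from compound 3 to compound 4

The source may report more compounds than this note shows. Statements on the series, on what has been measured and on what is new or still open speak of the compounds shown alone.

Of the compounds shown here, three have been measured in a functional assay, with stated times of 30 s and 6 min, in the presence of a further agent that is not named here; a higher number here means a weaker inhibitor, a lower number a stronger inhibitor. Compound 1 (`CCCCCCOc1cc(OC)c(Br)cc1C(C)=O`) gives 34000000 nM, compound 2 (`CCOc1cc(OC)ccc1C(C)=O`) gives 6600000 nM, and compound 3 (`CCCCOc1cc(OC)ccc1C(C)=O`) gives 15600000 nM. Compound 3 thus has the second highest of the three numbers, making it a weaker inhibitor than compound 2 and a stronger one than compound 1.

Compound 4 (`CCCCCCOc1cc(OC)ccc1C(C)=O`) has not yet been measured. Its difference from compound 3 is this: ethyl in place of hydrogen on a saturated chain carbon, four bonds along the chain from an oxygen on an aromatic ring. Going by the values given here, one measured step bears on the change. Ethyl in place of hydrogen, two bonds along the chain from an oxygen on an aromatic ring, gave a 2.4-fold higher number from compound 2 to compound 3 (0.37 log units; beyond the scatter), a modest move towards weaker inhibition. This is a single precedent at a different chain carbon, so the expectation is tentative: a step of similar modest size in the same direction. The estimated value for compound 4 is 32000000 nM, with an expected range of 14000000 nM to 75000000 nM. This expected value corresponds to a 2.1-fold higher number from compound 3 to compound 4 (0.31 log units; beyond the scatter).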

Compound 4, half-maximal inhibitory concentration: 18000000 nM
The estimate for compound 4 lay 1.8-fold (0.25 log units) above the measured number; the measured number falls inside the stated range.
By their numbers in this assay, from the lowest: compound 2; then compounds 3, 4 and 1 (each within the scatter of the next, the first and the last beyond it).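

In this assay ethyl in place of hydrogen, four bonds along the chain from an oxygen on an aromatic ring, gives a 1.2-fold higher number from compound 3 to compound 4 (0.06 log units; within the scatter) and so stays within the scatter, unlike the step two bonds along the chain, which gave a 2.4-fold higher number from compound 2 to compound 3 (0.37 log units; beyond the scatter) and lay beyond it. Taken whole, butyl in place of hydrogen two bonds along the chain gives a 2.7-fold higher number from compound 2 to compound 4 (0.44 log units; beyond the scatter) and remains a modest move towards weaker inhibition. Hydrogen in place of bromo on an aromatic carbon gives a 1.9-fold lower number from compound 1 to compound 4 (0.28 log units; within the scatter) and lies within the scatter, so on these numbers bromo cannot be told apart from hydrogen there.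

Nothing available accounts for these numbers.

Going by these compounds, whether a longer chain, an amine or a carboxylic acid in place of the ether chain would shift the number remains open.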